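The source may report more compounds than this note shows. Statements on the series, on what has been measured and on what is new or still open speak of the compounds shown alone.

Compound 2 has the structure `Cc1ccc(-c2csc(N)c2C(=O)OCc2ccccc2)cc1`. In an assay on isolated protein for inhibition of protein kinase C zeta type (Homo sapiens), with stated times of 1 h and 2.5 min, tested at 30 uM (a lower number here means less inhibition, a higher number more inhibition at the concentration tested (going by the name of the read-out)), compound 2 gives 60%, the lowest of the two numbers measured here. Its nearest neighbour is compound 1, with the structure `CCOC(=O)c1c(-c2ccc(C)cc2)csc1N`, in which compound 1 gives 80%. Among the measured compounds shown here, the one measured step between these two, a number 20 percentage points lower from compound 1 to compound 2 (beyond the scatter), changed the ester part and nothing else.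

Compound 3 has the structure `Nc1scc(-c2ccccc2F)c1C(=O)OCc1ccccc1` and has not been measured. It differs from compound 2 in one place: 2-fluorophenyl in place of 4-methylphenyl on an aromatic carbon. This change sits on the five-membered aromatic ring with one sulfur, far from the ester that was varied in the measured step. For the measured compounds named here, no measured pair in this set changes the group on that aromatic carbon, so nothing here shows how this assay responds to such a change, and the step from compound 1 to compound 2 gives no guidance for it. The expectation is therefore a step of about a number 5 percentage points lower from compound 2 to compound 3 (within the scatter), that is, no change beyond the scatter, with a wide range. Compound 3 is thus estimated at 55%, within 30% to 80%.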

Compound 3, a percentage reported as inhibition, at one concentration (the size of the read-out at that concentration, not a potency): 57%
Estimate against measurement, compound 3: 2 percentage points below, within the range that was stated.
By their numbers in this assay, from the lowest: compounds 3 and 2 (each within the scatter of the next); then compound 1.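

Among the compounds shown here, this is the first look at the aromatic carbon of the five-membered aromatic ring with 1 sulfur, and in this assay putting 2-fluorophenyl in place of 4-methylphenyl gives a number 3 percentage points lower from compound 2 to compound 3 (within the scatter) on the shared core. The read-out therefore does not separate these two groups, even though they differ both in the substituent they carry and in where it sits on the phenyl ring, whereas the change at the ester gave a number 20 percentage points lower from compound 1 to compound 2 (beyond the scatter) and did stand out from the scatter. Nothing available here explains why this exchange leaves the read-out unmoved.

Going by these compounds, only 4-methylphenyl and 2-fluorophenyl are compared on this carbon, so it remains open whether a carboxylic acid or an amine on that phenyl ring, or a short alkyl chain in place of the ring, would be equally indistinguishable. On these data alone, it also remains open whether 2-fluorophenyl would match 4-methylphenyl alongside the ethyl ester of compound 1, and since each number comes from a single concentration, how potency compares across these compounds is unknown too.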